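Aryl Replacement on the Shared Core: Compound 3 to Compound 4

The compounds below may be only part of what the source reports. "The series", "measured", "known", "first", "only" and "open" are said of these compounds alone.

Three analogues on a shared core, compound 1 (`CCOC(=O)CN(Cc1ccccc1)c1nc(NCc2cccc(OC)c2)ncc1[N+](=O)[O-]`), compound 2 (`CCOC(=O)CN(Cc1ccccc1)c1nc(Nc2ccccc2)ncc1[N+](=O)[O-]`) and compound 3 (`CCOC(=O)CN(Cc1ccccc1)c1nc(Nc2cc(OC)c(OC)c(OC)c2)ncc1[N+](=O)[O-]`), have been run in a functional assay on HepG2 cells (Homo sapiens) for antiproliferative activity, read by MTT assay, with a stated time of 48 h; a higher number here means a weaker inhibitor, a lower number a stronger inhibitor. Compound 1 gives 33600 nM, compound 2 gives 44400 nM and compound 3 gives 37800 nM. Compound 3 holds the second highest number of the three, yet every gap among them is within the scatter: a 1.3-fold higher number from compound 1 to compound 2 (0.12 log units; within the scatter) and a 1.1-fold higher number from compound 1 to compound 3 (0.05 log units; within the scatter). Compound 4 (`CCOC(=O)CN(Cc1ccccc1)c1nc(Nc2ccc(Cl)cc2)ncc1[N+](=O)[O-]`) differs from compound 3 by 4-chlorophenyl in place of 3,4,5-trimethoxyphenyl on a nitrogen on an aromatic ring. Among the compounds with values here, the one aryl-to-aryl step seen so far, a 1.2-fold lower number from compound 2 to compound 3 (0.07 log units; within the scatter), stayed within the scatter, as did the benzyl-to-aryl steps, so this assay is expected to shift by no more than the scatter here. The expected step is a 1.1-fold higher number from compound 3 to compound 4 (0.02 log units; within the scatter). For compound 4 the estimate is 40000 nM, ranging from 20000 nM to 80000 nM.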

Compound 4, half-maximal inhibitory concentration: 30900 nM
Estimate against measurement, compound 4: 1.3-fold (0.11 log units) above; low and high end bracket the measured number.
By their numbers in this assay, from the lowest: compounds 4, 1, 3 and 2 (each within the scatter of the next).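

On a nitrogen on an aromatic ring, 4-chlorophenyl brings the first chlorine to the series, and in this assay it stays level with 3,4,5-trimethoxyphenyl (a 1.2-fold lower number from compound 3 to compound 4 (0.09 log units; within the scatter)) and with 3-methoxybenzyl (a 1.1-fold lower number from compound 1 to compound 4 (0.04 log units; within the scatter)). Chloro in place of hydrogen on an aromatic carbon, the first single-atom change here, also stays within the scatter (a 1.4-fold lower number from compound 2 to compound 4 (0.16 log units; within the scatter)). No evidence is available to account for these results.

As far as these compounds go, whether an amine or a carboxylic acid on this aryl ring would move the number beyond the scatter remains open. So does the response to a longer chain on that nitrogen.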